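Swapping Fluoro for Thiophene on a Tolerated Amide

This account rests on a few compounds, and the source may have more. Where it says the series, first, only, none or still open, it means among the compounds named here.

Measured compounds and values:
compound 1 `O=C(NCc1ccc(F)cc1)c1cccc(O)c1O` gives > 40000 nM.
compound 2 `O=C(NCc1ccc(F)cc1)c1cccc(OCc2ccccc2)c1O` gives > 40000 nM.
compound 3 `O=C(NCc1ccc(F)c(F)c1)c1cccc(O)c1O` gives > 40000 nM.

All three compounds share one core, an amide linking a dihydroxylated benzene to a benzyl group. In an ADME assay on NCI-H630 cells (Homo sapiens) for cytotoxicity, read by MTT assay, with a stated time of 72 h (a higher number here means that more compound is tolerated, a lower number that less compound is tolerated), compound 1 gives > 40000 nM, which is a limit of the assay rather than a number. Compound 2 likewise gives > 40000 nM, again a limit. Compound 3 gives > 40000 nM, also a limit. Because of the limit of > 40000 nM in this assay, at which 3 of the 3 values shown sit, neither measured step can be sized: a step that the two limits leave unreadable from compound 1 to compound 2 and a step that the two limits leave unreadable from compound 1 to compound 3 both stay hidden behind the limit.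

Compound 4 `O=C(NCc1ccc(-c2cccs2)cc1)c1cccc(O)c1O` takes the step (thiophen-2-yl in place of fluoro on an aromatic carbon). The two known steps on this core, one adding benzyl to an oxygen and one adding fluoro to the benzyl ring, bear on it only by showing that changes of this kind have not yet brought a compound below the limit. No direction or size of step can be read for compound 4 in this assay from those steps; the expectation is therefore that compound 4 again sits at the limit, with a number no higher from compound 1 to compound 4 (the limit leaves the size open) expected to be unreadable. Compound 4 is estimated at 40000 nM, with a range from 15000 nM to 100000 nM.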

Compound 4, half-maximal cytotoxic concentration: 15000 nM
Estimate against measurement, compound 4: 2.7-fold (0.43 log units) above, within the range that was stated.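

In this assay, going by these compounds alone, thiophen-2-yl in place of fluoro on this aromatic carbon gives an at least 2.6-fold lower number from compound 1 to compound 4 (0.42 log units; beyond the scatter), the first step on the shared core that can be read. This position is therefore not indifferent to what it carries: a group of 5 heavy atoms with its own five-membered aromatic ring, in place of a single fluorine, brings the compound within the measurable range, so that less of it is tolerated by the cells. The step is only a minimum, and the other steps on this core cannot be read at all, because compound 1 and the compounds compared with it so far stand at a limit rather than at a number: the limit of > 40000 nM in this assay, at which 3 of the 4 values shown sit.

On these data alone, with a single replacement at this carbon, it remains open whether the thiophene ring matters as such or whether a plain phenyl ring, a longer chain, an amine or a carboxylic acid in the same place would lower the number too. As far as these compounds go, it is also open how far the number would move if the benzyl group on the oxygen of compound 2 were combined with the thiophen-2-yl group of compound 4.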